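The source may report more compounds than this note shows. Statements on the series, on what has been measured and on what is new or still open speak of the compounds shown alone.

Three compounds sharing one core have gone through a physicochemical assay for solubility, read by nephelometry (on this read-out higher numbers stand for higher solubility and lower numbers for lower solubility), and none of them has given a number. Compound 1 `COc1ccc(CNc2cc(CN3C(=O)N(c4ccc(SC(F)(F)F)cc4)C(=O)C3(C)C)ccn2)cc1` reads < 0.027 ug/mL, which is a limit. Compound 2 `CC1(C)C(=O)N(c2ccc(SC(F)(F)F)cc2)C(=O)N1Cc1ccnc(NCc2ccccc2)c1` reads < 0.026 ug/mL, also a limit. Compound 3 `CCc1cc(CN2C(=O)N(c3ccc(SC(F)(F)F)cc3)C(=O)C2(C)C)ccn1` reads < 0.022 ug/mL, again a limit, so it has no exact place among the three.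

Compound 4 `CC(C)Nc1cc(CN2C(=O)N(c3ccc(SC(F)(F)F)cc3)C(=O)C2(C)C)ccn1` has not yet been measured. It has isopropylamino in place of ethyl on an aromatic carbon, next to the ring nitrogen: isopropylamino in place of ethyl on an aromatic carbon. The closest guides are the two measured swaps between an amino group and ethyl, a step that the two limits leave unreadable from compound 1 to compound 3 and a step that the two limits leave unreadable from compound 2 to compound 3. Neither has a readable size, and neither does a step that the two limits leave unreadable from compound 1 to compound 2. With no measured size to carry over, no step beyond the scatter is expected in this assay, and another limit is the likeliest result. The expected outcome is an at least 1.0-fold higher number from compound 3 to compound 4 (0.03 log units; that floor lies within the scatter). For compound 4 the estimate is 0.024 ug/mL, with an expected range from 0.01 ug/mL to 0.08 ug/mL.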

Compound 4, solubility: < 0.023 ug/mL
Compound 4: a limit, no number; the forecaster's own chance of this, stated with the estimate: 85%; at least 1.0-fold (0.01 log units) between middle value and limit.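

Compound 4 gives only a limit, as do compound 1, compound 2 and compound 3, and no step among these four compounds can be read in this assay. The compounds shown leave open whether changing the group on that aromatic carbon alters solubility at all, and by how much.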